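Swapping a Methylbenzyl for a tert-Butylphenyl on a Shared Core

The compounds below may be only part of what the source reports. "The series", "measured", "known", "first", "only" and "open" are said of these compounds alone.

The study measures an ADME assay on L02 cells (Homo sapiens) for inhibition, read by CCK-8 assay, with a stated time of 48 h; a lower number here means a stronger inhibitor of growth, a higher number a weaker inhibitor of growth. Compound 1 `Cc1ccccc1Nc1nc(NC2CCCCC2)ncc1Cl` reports only the assay limit, > 100000 nM. Compound 2 `Cc1ccc(Nc2ncc(Cl)c(Nc3ccccc3C)n2)cc1` likewise reaches only the limit, > 100000 nM. The step that the two limits leave unreadable from compound 1 to compound 2 therefore cannot be read. Compound 3 `Cc1ccc(CNc2nc(Nc3ccc(N4CCN(C)CC4)cn3)ncc2Cl)cc1` also sits at the limit, > 100000 nM, and that is all that is known of it. Compound 4 `CN1CCN(c2ccc(Nc3ncc(Cl)c(Nc4ccc(C(C)(C)C)cc4)n3)nc2)CC1` differs from compound 3 by 4-(tert-butyl)phenyl in place of 4-methylbenzyl on a nitrogen on an aromatic ring. For the measured compounds named here, no measured step covers this change; the only evidence is the limit of > 100000 nM in this assay, at which 3 of the 3 values shown sit, so no movement beyond the scatter is expected, and the outcome will most likely again be a limit rather than a number. The step expected here is a step that the limit leaves unreadable from compound 3 to compound 4. Compound 4 is estimated at 150000 nM, within 60000 nM to 400000 nM.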

Compound 4, concentration for 50% growth inhibition: 6070 nM
Beside the measured number, compound 4's estimate is 25-fold (1.39 log units) above it; the measured number lies below the stated range.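

This position on the nitrogen can move the read-out: 4-(tert-butyl)phenyl in place of 4-methylbenzyl gives an at least 16-fold lower number from compound 3 to compound 4 (1.21 log units; beyond the scatter) in this assay. The earlier steps could not be read, and compound 4 is the only compound here with a number rather than a limit: the limit of > 100000 nM in this assay, at which 3 of the 4 values shown sit.

The change swaps benzyl for phenyl and methyl for tert-butyl at once, so the compounds shown cannot separate the two. As far as these compounds go, whether 4-(tert-butyl)benzyl, or an amine or carboxylic acid in place of the tert-butyl, would give a number also stays open.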